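A Cyclopropyl Amide Step Repeated on a Second Core

The compounds below may be only part of what the source reports. "The series", "measured", "known", "first", "only" and "open" are said of these compounds alone.

Three compounds have so far been measured in a functional assay on the whole organism with Mus musculus as the target, in the rotarod test; on this read-out lower numbers stand for an effect already at smaller amounts and higher numbers for an effect only at larger amounts of compound:

Compound 1 `O=C(/C=C1\CCc2cc(F)cc(F)c21)NC1CC1`: 81 mg/kg
Compound 2 `NC(=O)/C=C1\CCc2cc(F)cc(F)c21`: 81 mg/kg
Compound 3 `NC(=O)/C=C1\CCc2ccc(F)cc21`: 90 mg/kg

Compound 4 `O=C(/C=C1\CCc2ccc(F)cc21)NC1CC1` has not yet been measured. It differs from compound 3 by cyclopropyl in place of hydrogen on an amide-type nitrogen. The same change, (cyclopropyl in place of hydrogen on an amide-type nitrogen), is already covered by a measured pair: it gave no change at the digits printed from compound 2 to compound 1 (within the scatter). The place of the change is described in the same words for both pairs, so it is the same change on two cores. How the core of compound 3 differs from the core of compound 2 is not broken down here; the values of compound 3 and compound 2 in this assay lie within the scatter of each other, as do those of compound 3 and compound 1.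

For compound 4 in this assay the step from compound 3 is expected to be no change at the digits printed from compound 3 to compound 4 (within the scatter), resting on the measured pair because no change at the digits printed from compound 2 to compound 1 (within the scatter) showed no change. Compound 4 is therefore estimated at 90 mg/kg, between 55 mg/kg and 150 mg/kg.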

Compound 4, dose for half-maximal effect: 62 mg/kg
The estimate for compound 4 lay 1.5-fold (0.16 log units) above the measured number, and the stated range covers the measured number.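

Replacing the amide hydrogen by cyclopropyl gave in this assay a 1.5-fold lower number from compound 3 to compound 4 (0.16 log units; within the scatter). Set beside the earlier pair, the change reads alike on the two cores: the same change on two cores in this assay, no change at the digits printed (within the scatter) from compound 2 to compound 1 and a 1.5-fold lower number (0.16 log units; within the scatter) from compound 3 to compound 4, 1.5-fold (0.16 log units) apart, within the scatter of two such steps. This shows that, on these two cores, the change carried over without a step beyond the scatter, but it does not show that cyclopropyl raises or lowers the dose needed for the effect, nor that the same would hold on any further core.

With only hydrogen and cyclopropyl on that nitrogen, the compounds shown leave open whether a cyclohexyl ring, a longer chain or a chain carrying an amine would give a step beyond the scatter in this assay. They also leave open whether the change would read the same on a core carrying chlorine or methoxy in place of fluorine.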